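This account rests on a few compounds, and the source may have more. Where it says the series, first, only, none or still open, it means among the compounds named here.

The series under consideration is built on a cinnamic hydroxamate core. Compound 1 `CC(=O)ONC(=O)/C=C/c1ccccc1OC(=O)c1ccccc1` carries an acetyl group on the hydroxamate oxygen and a benzoate ester on the phenol. In a functional assay on NCI-H23 cells (Homo sapiens) for inhibition, read by ELISA, with a stated time of 24 h (on this read-out lower numbers stand for stronger inhibition of growth and higher numbers for weaker inhibition of growth), compound 1 gives 26300 nM. The related compound 2 `O=C(/C=C/c1ccccc1O)NO`, in which both of those oxygens are free, gives in this assay a value of 27800 nM. Compound 1 shows the lower of the two numbers, but the gap to compound 2 is within the usual scatter, so the two cannot be told apart on this read-out.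

Compound 3 `CN1CCN(C(=O)ONC(=O)/C=C/c2ccccc2OC(=O)c2ccccc2)CC1` differs from compound 1 in one place: 4-methylpiperazin-1-yl in place of methyl on a carbonyl carbon. For the measured compounds named here, no pair in the measured set shows this kind of change, so its effect in this assay cannot be read from the data; the only guidance is that the two measured compounds sit close together. The step from compound 1 to compound 3 is therefore expected to be small, a 1.1-fold lower number from compound 1 to compound 3 (0.02 log units; within the scatter), with no clear direction beyond the scatter. Compound 3 is expected to give 25000 nM in this assay, within a range from 10000 nM to 60000 nM.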

Compound 3, concentration for 50% growth inhibition: 45200 nM
Compound 3: the middle estimate sits 1.8-fold (0.26 log units) below what was measured; the measured number falls inside the stated range.
By their numbers in this assay, from the lowest: compounds 1, 2 and 3 (each within the scatter of the next).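

For the compounds shown here, the exchange of methyl for 4-methylpiperazin-1-yl on a carbonyl carbon gives, in this assay, a 1.7-fold higher number from compound 1 to compound 3 (0.24 log units; within the scatter) and is the first change that can be read at a single place, since compound 1 and compound 2 differ in two. Going by these compounds alone, it shows that this place on the hydroxamate oxygen accepts a much larger group, one that brings in a six-membered non-aromatic ring with 2 hetero atoms, with no step that can be told from the scatter of the measurement. Nothing available offers any explanation for this result.

The compounds shown leave open how a carboxylic acid, a primary amine or a longer alkyl chain would read on this carbonyl carbon, and whether any replacement here would produce a step beyond the scatter. They also leave unresolved what the acetyl group and the benzoate ester each contribute on their own, as the two change together between compound 1 and compound 2.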